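This account rests on a few compounds, and the source may have more. Where it says the series, first, only, none or still open, it means among the compounds named here.

Measured so far in a functional assay on U-373MG ATCC cells (Homo sapiens) for cytotoxicity, read by MTT assay (on this read-out lower numbers stand for stronger inhibition and higher numbers for weaker inhibition), are three compounds
- compound 1 `Oc1ccc(CN(Cc2ccccc2)Cc2ccc(O)c3ncccc23)c2cccnc12` with 357 nM
- compound 2 `Oc1ccc(CN(Cc2ccccc2C(F)(F)F)Cc2ccc(O)c3ncccc23)c2cccnc12` with 78 nM
- compound 3 `Oc1ccc(CN(Cc2cc(C(F)(F)F)cc(C(F)(F)F)c2)Cc2ccc(O)c3ncccc23)c2cccnc12` with 96 nM

Compound 2 at 78 nM and compound 3 at 96 nM lie within the usual scatter of each other, and both numbers are lower than that of compound 1 at 357 nM on this scale.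

Compound 4 `Oc1ccc(CN(Cc2cccc(I)c2)Cc2ccc(O)c3ncccc23)c2cccnc12` has not been measured yet. It differs from compound 2 in one place (3-iodophenyl in place of 2-(trifluoromethyl)phenyl on a saturated chain carbon bound to an amine nitrogen), where 3-iodophenyl stands in place of 2-(trifluoromethyl)phenyl on a saturated chain carbon bound to an amine nitrogen.

Within the data shown here, one measured step bears on this change. It is a 4.6-fold lower number from compound 1 to compound 2 (0.66 log units; beyond the scatter) when trifluoromethyl replaces hydrogen on an aromatic carbon, a modest step beyond the scatter. Compound 3 also carries trifluoromethyl and stands at 96 nM in the same range as compound 2. Among the measured compounds shown here, no measured compound carries iodine, so the data offer only an indirect guide. Compound 4 keeps a substituent on that aromatic ring, so it is expected to stay closer to compound 2 than to compound 1. The expected change is small and toward a higher number, a 1.5-fold higher number from compound 2 to compound 4 (0.19 log units; within the scatter) in this assay and probably not beyond the scatter. For compound 4 the estimated value is 120 nM with an expected range from 45 nM to 320 nM in all.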

Compound 4, half-maximal inhibitory concentration: 5600 nM
Compound 4: middle estimate off by 47-fold (1.67 log units), on the low side; measured number outside the range, above it.
By their numbers in this assay, from the lowest: compounds 2 and 3 (each within the scatter of the next); then compound 1; then compound 4.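

In this assay, among these compounds, the benzyl group on the amine nitrogen turns out to matter far more than the earlier compounds suggested: going from 2-(trifluoromethyl)benzyl to 3-iodobenzyl gives a 72-fold higher number from compound 2 to compound 4 (1.86 log units; beyond the scatter), a much larger shift than any seen before. Keeping a substituent on this ring therefore does not by itself hold the number low, and iodo in place of hydrogen gives a 16-fold higher number from compound 1 to compound 4 (1.20 log units; beyond the scatter), the opposite direction from a 4.6-fold lower number from compound 1 to compound 2 (0.66 log units; beyond the scatter) seen with trifluoromethyl. The same ring can thus move the number either way depending on what it carries, and nothing measured here explains this difference.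

The compounds shown leave open whether the rise follows the iodine itself or where it sits on the ring, as 3-iodophenyl and 2-(trifluoromethyl)phenyl differ in both; placing trifluoromethyl where compound 4 holds its iodine, and iodine where compound 2 holds its trifluoromethyl, would separate the two. As far as these compounds go, it also remains open whether a bromine or a chlorine in place of the iodine of compound 4 would give a similarly high number.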